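The source may hold more compounds than are shown below. What is called first, only, known or untested is meant among the compounds shown, and "the series" means these compounds.

Of the compounds shown here, three sharing one core have been tested in a functional assay on the whole organism for inhibition, with Cavia porcellus as the target; a higher number here means that more compound is needed for the effect, a lower number that less compound is needed: compound 1 `CN(C)/C(=N\C#N)C1=CC(C)(C)Oc2ccc([N+](=O)[O-])cc21`, compound 2 `CN(C)/C(=N\C#N)C1=CC(C)(C)Oc2ccc(S(=O)(=O)c3ccccc3)cc21` and compound 3 `CN(C)/C(=N\C#N)C1=CC(C)(C)Oc2ccc(S(C)(=O)=O)cc21`. With a nitro group, compound 1 gives 51.3 nM, and with phenylsulfonyl, compound 2 gives 3630 nM. With methylsulfonyl, compound 3 reads > 31600 nM, which is a limit of the assay and not a number.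

The untested compound 4 `CN(C)/C(=N\C#N)C1=CC(C)(C)Oc2ccc(C(F)(F)F)cc21` differs from compound 3 at one place: trifluoromethyl in place of methylsulfonyl on an aromatic carbon. Trifluoromethyl takes the place of methylsulfonyl on an aromatic carbon.

Among the measured compounds shown here, no measured step tests trifluoromethyl directly, but two measured steps change the group at this position. Both are large: a 71-fold higher number from compound 1 to compound 2 (1.85 log units; beyond the scatter) and an at least 610-fold higher number from compound 1 to compound 3 (2.78 log units; beyond the scatter). Replacing the sulfonyl group of compound 3 could therefore undo much of that rise, although trifluoromethyl is not nitro, so a full return to the level of compound 1 cannot be assumed.

In this assay, a large move to a lower number is expected, estimated as an at least 79-fold lower number from compound 3 to compound 4 (1.89 log units; beyond the scatter). For compound 4 the estimate is 400 nM, with an expected range from 70 nM to 2500 nM.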

Compound 4, half-maximal effective concentration: 178 nM
Estimate against measurement, compound 4: 2.2-fold (0.35 log units) above; measured number inside the range.
By their numbers in this assay, from the lowest: compound 1; then compound 4; then compound 2. At a limit, above all of these: compound 3.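

Swapping methylsulfonyl for trifluoromethyl in this assay recovers most of the lost ground (an at least 170-fold lower number from compound 3 to compound 4 (2.24 log units; beyond the scatter)), and swapping phenylsulfonyl for it gives a similarly large move (a 20-fold lower number from compound 2 to compound 4 (1.31 log units; beyond the scatter)). Nitro is therefore no longer the only group shown at this position with a low number, and both sulfonyl compounds now sit well above two other groups, although trifluoromethyl does not fully match nitro (a 3.5-fold higher number from compound 1 to compound 4 (0.54 log units; beyond the scatter)). The value of compound 3 is a limit of the assay and not a number, so its step gives only a minimum size: (the limit of > 31600 nM in this assay, at which 1 of the 4 values shown sits).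

Four groups at one position cannot show which feature of a group sets the number. From the compounds shown here alone, how an amine, a carboxylic acid or a methoxy group would behave here remains open.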